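Trifluoromethyl in Place of Methyl on the Thioether Benzyl

This account rests on a few compounds, and the source may have more. Where it says the series, first, only, none or still open, it means among the compounds named here.

Three measured compounds share one core. In a functional assay on PC-9 cells (Homo sapiens) for inhibition, read by MTT assay, with a stated time of 72 h (on this read-out higher numbers stand for weaker inhibition and lower numbers for stronger inhibition), compound 1 `Cc1cc(Nc2cc(-c3ccccc3)[nH]n2)n2nc(SCCCc3ccccc3)nc2n1` gives 5030 nM, compound 2 `Cc1ccc(CSc2nc3nc(C)cc(Nc4cc(-c5ccccc5)[nH]n4)n3n2)cc1` gives 7310 nM, and compound 3 `Cc1cc(Nc2ccn(Cc3nc(C)c4ccccc4n3)n2)n2nc(SCc3ccc(Br)cc3)nc2n1` gives 5450 nM. Compound 2 holds the highest of the three numbers, yet both others lie within the scatter of it. Compound 4 `Cc1cc(Nc2cc(-c3ccccc3)[nH]n2)n2nc(SCc3ccc(C(F)(F)F)cc3)nc2n1` differs from compound 2 by trifluoromethyl in place of methyl on an aromatic carbon. For the measured compounds named here, the one measured step that bears on this position, altering the group on the carbon bound to the sulfur, is a 1.5-fold higher number from compound 1 to compound 2 (0.16 log units; within the scatter), within the scatter. Going by the values given here, no measured pair exchanges a methyl for a trifluoromethyl, so in this assay no step beyond the scatter is expected: a 1.0-fold lower number from compound 2 to compound 4 (0.02 log units; within the scatter). Compound 4 is therefore estimated at 7000 nM, between 3000 nM and 16000 nM.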

Compound 4, half-maximal inhibitory concentration: 4240 nM
Compound 4: the middle estimate sits 1.7-fold (0.22 log units) above what was measured; low and high end bracket the measured number.
By their numbers in this assay, from the lowest: compounds 4, 1, 3 and 2 (each within the scatter of the next).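

In this assay, trifluoromethyl in place of methyl on the aromatic carbon para to a large group gives a 1.7-fold lower number from compound 2 to compound 4 (0.24 log units; within the scatter), the first step read at this aromatic carbon, and it stays within the scatter. 4-(Trifluoromethyl)phenyl in place of phenethyl on the saturated chain carbon bound to the sulfur gives a 1.2-fold lower number from compound 1 to compound 4 (0.07 log units; within the scatter), so compounds 1, 2 and 4 show no step beyond the scatter at this thioether substituent. No evidence is available to explain these steps. As far as these compounds go, whether an amine or a carboxylic acid on this aromatic carbon would give a step beyond the scatter remains open.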